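Swapping Cyclopropyl for Isopropyl on a Weak Agonist

This account rests on a few compounds, and the source may have more. Where it says the series, first, only, none or still open, it means among the compounds named here.

Of the compounds shown here, two have so far been measured in a functional assay on CHO-K1 cells for agonist activity at G-protein coupled receptor 6 (Homo sapiens), read by TR-FRET and cAMP accumulation, with a stated time of 20 h; on this read-out lower numbers stand for an effect already at smaller amounts and higher numbers for an effect only at larger amounts of compound. Compound 1, `CN(C)C(=O)c1ccc2nc(NC3CC3)c(N3CCN(Cc4cc(Cl)ccc4Cl)CC3)nc2c1`, gives 90 nM. Compound 2, `Cc1cc2nc(NC3CC3)c(N3CCC(Oc4ccc(F)cc4F)CC3)nc2cn1`, gives 29000 nM, the higher of the two numbers and far beyond the scatter from compound 1; the two structures differ in several places at once, so this gap cannot be traced to any single change. Compound 3, `Cc1cc2nc(NC(C)C)c(N3CCC(Oc4ccc(F)cc4F)CC3)nc2cn1`, differs from compound 2 in one place only: isopropyl in place of cyclopropyl on a nitrogen on an aromatic ring. The group keeps its size and adds no donor or acceptor; the small ring is opened into a branched chain. Among the compounds with values here, no measured pair shows such an exchange, so the step is expected to be small in this assay, possibly none beyond the scatter. The expected step from compound 2 to compound 3 is a 1.0-fold higher number from compound 2 to compound 3 (0.01 log units; within the scatter). Compound 3 is therefore estimated at 30000 nM, with a range from 10000 nM to 90000 nM.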

Compound 3, half-maximal effective concentration: 16000 nM
For compound 3 the middle estimate is 1.9-fold (0.27 log units) above the measured one; the range from low to high includes it.
By their numbers in this assay, from the lowest: compound 1; then compounds 3 and 2 (each within the scatter of the next).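

In this assay, within the data shown here, opening the three-membered ring of cyclopropyl into the branched isopropyl group on this nitrogen gives a 1.8-fold lower number from compound 2 to compound 3 (0.26 log units; within the scatter) and is the first exchange at this position that can be read on its own. For this pair, then, the ring can be opened with no change beyond the usual scatter, as long as the number of carbons stays the same. Nothing available explains why the two groups read alike.

Going by these compounds, this is one pair on a single core, so it remains open whether the same exchange would read alike on compound 1, which differs from compound 2 in several places. On these data alone, it also remains open whether a longer chain such as butyl, or a plain amine, on this nitrogen would move the number beyond the scatter.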